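Aryl exchange at the core; expected solubility of compound 3

A few compounds are considered here, and "the series" means these few. Any claim that something is new, unique, unknown or untested is made for them only; others in the source may bear on it.

Going by the values given here, compound 2 `Cn1c(-c2ccncc2)c(C2CCCC2)c2ccc(C(=O)NC3(C(=O)Nc4ccc(/C=C/C(=O)O)cc4)CCC3)cc21` gives 7 ug/mL in a physicochemical assay for solubility, using the shake flask method, in phosphate buffer, with a stated time of 24 h, at pH 7.2 (a higher number here means a more soluble compound, a lower number a less soluble compound), the higher of the two numbers measured so far; the other compound, compound 1 `COc1ccc(-c2c(C3CCCC3)c3ccc(C(=O)NC4(C(=O)Nc5ccc(/C=C/C(=O)O)cc5)CCC4)cc3n2C)cn1`, gives 0.6 ug/mL. Among the compounds with values here, the only measured step, a 12-fold higher number from compound 1 to compound 2 (1.07 log units; beyond the scatter), concerns the same aromatic carbon of the core that is changed here, but replaces a different group, so it bears on the present step only indirectly: it shows that swapping the aromatic ring at this carbon can move the solubility by a large amount.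

Compound 3 `Cn1c(-c2cnccn2)c(C2CCCC2)c2ccc(C(=O)NC3(C(=O)Nc4ccc(/C=C/C(=O)O)cc4)CCC3)cc21` differs from compound 2 in one place: pyrazin-2-yl in place of pyridin-4-yl on an aromatic carbon. The ring that enters has the same size and the same count of heavy atoms as the one that leaves, with one more ring nitrogen and one more hydrogen-bond acceptor. Within the data shown here, no measured step tells how such an exchange acts here, so the expectation is a step of about a 1.3-fold higher number from compound 2 to compound 3 (0.11 log units; within the scatter), small and not clearly beyond the scatter, leaning to a slightly higher number. Compound 3 is expected to give 9 ug/mL in this assay, within a range of 3 ug/mL to 27 ug/mL.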

Compound 3, solubility: 49 ug/mL
Beside the measured number, compound 3's estimate is 5.4-fold (0.74 log units) below it; the whole stated range lies below it.
By their numbers in this assay, from the lowest: compound 1; then compound 2; then compound 3.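

At the aromatic carbon next to the ring nitrogen, this assay now holds a second exchange of one six-membered aromatic ring for another: pyrazin-2-yl in place of pyridin-4-yl goes with a 7.0-fold higher number from compound 2 to compound 3 (0.85 log units; beyond the scatter) although both groups have 6 heavy atoms and no net charge, so heavy-atom count does not separate these two compounds. Pyrazin-2-yl in place of 6-methoxypyridin-3-yl goes with an 82-fold higher number from compound 1 to compound 3 (1.91 log units; beyond the scatter) and is the largest step in the series, leaving compound 3 with the highest number of the three compounds. Nothing at hand bears on what lies behind these differences.

The compounds shown leave open how other groups at this carbon would read, such as pyrimidin-2-yl or a pyridine ring bearing an amine, and whether the pyrazin-2-yl step would hold with a different group in place of the cyclopentyl or with the carboxylic acid replaced by an amide. All three values come from this assay alone, and nothing shown tells how compound 3 reads in any other test.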